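Adding a Methoxy Group to an Oxalamide Aniline

This account rests on a few compounds, and the source may have more. Where it says the series, first, only, none or still open, it means among the compounds named here.

The three measured compounds share one core. Compound 1 `O=C(/C=C/c1cccc(F)c1)Nc1ccc2c(c1)COC2=O` gives 34 nM in a functional assay on cells (T-cell, Mus musculus) for inhibition; on this read-out higher numbers stand for weaker inhibition and lower numbers for stronger inhibition. Compound 2 `O=C(Nc1ccccc1)C(=O)Nc1ccc2c(c1)COC2=O` stands highest of the three numbers, at 36100 nM in this assay; the nearest is compound 3 `CN(Cc1ccccc1)C(=O)C(=O)Nc1ccc2c(c1)COC2=O`, which gives 14300 nM, a gap beyond the scatter, while the gap to compound 1 is far larger. Compound 4 `COc1ccc(NC(=O)C(=O)Nc2ccc3c(c2)COC3=O)cc1` has not yet been measured. It differs from compound 2 by a single change: methoxy in place of hydrogen on an aromatic carbon. Going by the values given here, no measured pair shows this change, so there is nothing to lean on beyond compound 2 itself. The step expected from compound 2 to compound 4 in this assay is a 1.3-fold lower number from compound 2 to compound 4 (0.11 log units; within the scatter), that is, no change beyond the scatter in either direction. Compound 4 is therefore estimated at 28000 nM, within a range of 9000 nM to 90000 nM.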

Compound 4, half-maximal inhibitory concentration: 153000 nM
Compound 4: the middle estimate sits 5.5-fold (0.74 log units) below what was measured; measured number outside the range, above it.
By their numbers in this assay, from the lowest: compound 1; then compound 3; then compound 2; then compound 4.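

In this assay, going by these compounds alone, the step of a 4.2-fold higher number from compound 2 to compound 4 (0.63 log units; beyond the scatter) is the first one here between compounds that differ in one place. It shows that the aromatic carbon para to a large group does not tolerate every substituent equally: going from phenyl to 4-methoxyphenyl weakens inhibition beyond the scatter. Nothing available gives a reason for this step.

The compounds shown leave open whether a smaller fluorine atom, a hydroxyl, an amine or a longer chain such as ethoxy at this place would also weaken inhibition. They also leave open whether methoxy on another carbon of this ring would do the same.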